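The compounds below may be only part of what the source reports. "The series", "measured", "known", "first", "only" and "open" are said of these compounds alone.

Working notes on the series around the shared core of compound 2 `Cc1cc(=O)n(-c2ccccc2C(F)(F)F)nc1C(=O)Nc1ccc(Oc2ncnc3c2ccn3C)cc1`, read in a functional assay on PC-3 cells (Homo sapiens) for cytotoxicity, read by MTT assay, with a stated time of 72 h; on this read-out lower numbers stand for stronger inhibition and higher numbers for weaker inhibition. Among the compounds with values here, compound 2 gives 19100 nM and is the only compound with a number in this assay. Compound 1 `Cc1cc(=O)n(-c2cccc(F)c2)nc1C(=O)Nc1ccc(Oc2ncnc3c2ccn3C)cc1` reaches only a limit in this assay, at > 60000 nM. Within the data shown here, the one measured step, an at least 3.1-fold lower number from compound 1 to compound 2 (0.49 log units; beyond the scatter), is therefore bounded on its starting side, as the limit of > 60000 nM in this assay, at which 1 of the 2 values shown sits, shows, and its true size is not known beyond its lower bound.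

Compound 3 `Cc1cc(=O)n(-c2ccccc2Cl)nc1C(=O)Nc1ccc(Oc2ncnc3c2ccn3C)cc1` differs from compound 2 by chloro in place of trifluoromethyl on an aromatic carbon. Among the measured compounds shown here, no measured step touches this position; the only step in hand changes the group on the aromatic nitrogen and so speaks only to that place. It shows that the ring carried by compound 2 gives a number at all where compound 1 does not, which is the sole anchor. With the phenyl retained and only the substituent exchanged, the expected step is a 1.0-fold higher number from compound 2 to compound 3 (0.02 log units; within the scatter), within scatter. Compound 3 is estimated at 20000 nM, ranging from 7000 nM to 60000 nM.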

Compound 3, half-maximal inhibitory concentration: 16400 nM
For compound 3 the middle estimate is 1.2-fold (0.09 log units) above the measured one, and the stated range covers the measured number.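

In this assay, the exchange on an aromatic carbon ortho to a large group gives a 1.2-fold lower number from compound 2 to compound 3 (0.07 log units; within the scatter), so this position tolerates chloro in place of trifluoromethyl without a change that can be read, even though a single chlorine replaces a group of 4 heavy atoms. Compound 3 also gives a second step on the aromatic nitrogen, an at least 3.6-fold lower number from compound 1 to compound 3 (0.56 log units; beyond the scatter), so the 2-chlorophenyl and 2-(trifluoromethyl)phenyl compounds both read as numbers while the 3-fluorophenyl compound does not. This second step is bounded on its starting side only, and its true size is not known beyond its lower bound: the limit of > 60000 nM in this assay, at which 1 of the 3 values shown sits.

The compounds shown do not separate the place of the substituent from its kind, since compound 1 differs from compound 3 in both at once. Also open, going by these compounds, is whether this position accepts a group of another type, such as an amine, a carboxylic acid or a longer alkyl chain, and whether any such group would move the number beyond the scatter.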